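Shifting the Carboxylate Out to a Carboxymethyl Group

A few compounds are considered here, and "the series" means these few. Any claim that something is new, unique, unknown or untested is made for them only; others in the source may bear on it.

For the measured compounds named here, compound 2 `O=C(O)c1cccc(NC(=O)C(C2CCCCC2)n2c(-c3ccc(Cl)cc3)nc3cc(F)c(F)cc32)c1` gives 10700 nM in a functional assay for agonist activity at Bile acid receptor (Homo sapiens), read by a luciferase reporter (on this read-out higher numbers stand for an effect only at larger amounts of compound and lower numbers for an effect already at smaller amounts), the only number among the values so far. Compound 1 `O=C(O)c1ccccc1NC(=O)C(C1CCCCC1)n1c(-c2ccc(Cl)cc2)nc2cc(F)c(F)cc21` returns only a limit in this assay, > 40000 nM. Going by the values given here, that limit of > 40000 nM in this assay, at which 1 of the 2 values shown sits, is where the step of an at least 3.7-fold lower number from compound 1 to compound 2 (0.57 log units; beyond the scatter) begins, and it is the one measured step that touches the carboxyphenyl group on the amide-type nitrogen. Compound 3 `O=C(O)Cc1ccc(NC(=O)C(C2CCCCC2)n2c(-c3ccc(Cl)cc3)nc3cc(F)c(F)cc32)cc1` carries the change (4-(carboxymethyl)phenyl in place of 3-carboxyphenyl on an amide-type nitrogen). The step from compound 1 to compound 2 shows that moving the acid around that ring can change the number by at least a modest amount, but it does not say which way a further move, now through the carboxymethyl group, will go. For compound 3 the expected step is therefore a 1.3-fold lower number from compound 2 to compound 3 (0.13 log units; within the scatter), close to no change but with wide uncertainty. The estimate for compound 3 in this assay is 8000 nM, between 2000 nM and 40000 nM.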

Compound 3, half-maximal effective concentration: 4900 nM
Estimate against measurement, compound 3: 1.6-fold (0.21 log units) above; measured number inside the range.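

In this assay, 4-(carboxymethyl)phenyl on the amide-type nitrogen gives a 2.2-fold lower number from compound 2 to compound 3 (0.34 log units; beyond the scatter), the first sign that this position accepts the acid on a carboxymethyl group and that the number can fall further than with 3-carboxyphenyl. Set against 2-carboxyphenyl, the same group gives an at least 8.1-fold lower number from compound 1 to compound 3 (0.91 log units; beyond the scatter). That step starts from compound 1, whose value is a limit and not a number: the limit of > 40000 nM in this assay, at which 1 of the 3 values shown sits.

The change moves the acid and adds the carboxymethyl carbon in a single step, and the compounds shown do not separate the two, which 4-carboxyphenyl or 3-(carboxymethyl)phenyl could do. Also open, on these data alone, is whether a longer chain, such as 4-(2-carboxyethyl)phenyl, or a tetrazole in place of the carboxylic acid, would lower the number further.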